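Bromo-to-chloro exchange across two related cores

This account rests on a few compounds, and the source may have more. Where it says the series, first, only, none or still open, it means among the compounds named here.

Measured so far in a functional assay on SK-MEL-2 cells (Homo sapiens) for cytotoxicity; a higher number here means a weaker inhibitor, a lower number a stronger inhibitor:
- compound 1, `O=C1NC(c2ccc(Br)cc2)CN1S(=O)(=O)c1ccc2c(c1)CCC2`: compound 1 gives 32600 nM
- compound 2, `O=C1NC(c2ccc(Cl)cc2)CN1S(=O)(=O)c1ccc2c(c1)CCC2`: compound 2 gives 64300 nM
- compound 3, `O=C1NCC(c2ccc(Br)cc2)N1S(=O)(=O)c1ccc2c(c1)CCC2`: compound 3 gives 119000 nM

Compounds 1 and 2 share one core and differ only by chloro in place of bromo on an aromatic carbon. The step is a 2.0-fold higher number from compound 1 to compound 2 (0.29 log units; within the scatter), so the two values cannot be told apart with confidence. Compound 3 carries the same atoms as compound 1 joined differently; the difference between the two cores is not broken down here. Its value stands within the scatter of compound 2 and beyond the scatter of compound 1.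

Compound 4, `O=C1NCC(c2ccc(Cl)cc2)N1S(=O)(=O)c1ccc2c(c1)CCC2`, is not yet measured. It differs from compound 3 by chloro in place of bromo on an aromatic carbon, the same change, at a place described in the same words, as between compound 1 and compound 2. For the measured compounds named here, with only one earlier instance, the expectation for the step to compound 4 rests on that single pair: the step of a 2.0-fold higher number from compound 1 to compound 2 (0.29 log units; within the scatter) was within the scatter, so the estimated step of a 1.5-fold higher number from compound 3 to compound 4 (0.18 log units; within the scatter) is taken to be of similar size and direction, while the range is kept wide given the single precedent and the position of compound 3 near the top of the measured values. On this basis compound 4 is expected to give about 180000 nM in this assay, with a likely range from 70000 nM to 400000 nM.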

Compound 4, half-maximal inhibitory concentration: 161000 nM
Beside the measured number, compound 4's estimate is 1.1-fold (0.05 log units) above it; measured number inside the range.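

In this assay, 4-bromophenyl to 4-chlorophenyl on the second core gives a 1.4-fold higher number from compound 3 to compound 4 (0.13 log units; within the scatter), and this step does not differ from the one seen on the first core: the same change on two cores in this assay, a 2.0-fold higher number (0.29 log units; within the scatter) from compound 1 to compound 2 and a 1.4-fold higher number (0.13 log units; within the scatter) from compound 3 to compound 4, 1.5-fold (0.16 log units) apart, within the scatter of two such steps

On these two cores, the exchange therefore carries over with no detectable difference in the size of the step. This does not show that the exchange itself has a real effect on the read-out, since each step taken alone lies within the scatter, and the shared direction of two such small steps cannot be treated as a trend. Nor does it show how the same exchange would behave on any core beyond these two, and the data give no explanation for the result on either core.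

As far as these compounds go, only bromo and chloro appear at this position, so it remains open whether a group such as methoxy, an amine or a carboxylic acid in their place would produce a step beyond the scatter on either core. The group on the sulfonyl is also the same in all four compounds, which leaves open what a replacement there, such as a simple phenyl or methyl group, would do to the read-out.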